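The source may hold more compounds than are shown below. What is called first, only, known or untested is meant among the compounds shown, and "the series" means these compounds.

Compound 1 `C=CCNC(=O)Nc1nc2cc(-c3cccnc3)c(=O)n(CCC(C)C)c2s1`: 0.03
Compound 2 `CCNC(=O)Nc1nc2cc(-c3ccc(OC)nc3)c(=O)n(C(C)C)c2s1`: 0.05

Within the data shown here, both compounds have been tested in an ADME assay on a cell-free system (plasma, Homo sapiens); on this read-out lower numbers stand for a smaller free fraction and higher numbers for a larger free fraction. Compound 2, at 0.05, lies within the usual scatter of compound 1, at 0.03, so the two cannot be told apart on this measure. They also differ in more than one place, so their numbers say nothing about any single change. Compound 3 `CCNC(=O)Nc1nc2cc(-c3cncc(C#N)c3)c(=O)n(C(C)C)c2s1` keeps everything in compound 2 except one group: 5-cyanopyridin-3-yl in place of 6-methoxypyridin-3-yl on an aromatic carbon. Here 5-cyanopyridin-3-yl stands in place of 6-methoxypyridin-3-yl on an aromatic carbon. Among the measured compounds shown here, no measured pair shows what this swap does, so no step beyond the scatter is expected, and no direction can be favoured. The expected change is no change at the digits printed from compound 2 to compound 3 (within the scatter). For compound 3 the estimated value is 0.05, with an expected range of 0.025 to 0.1.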

Compound 3, unbound fraction: 0.1
For compound 3 the middle estimate is 2.0-fold (0.30 log units) below the measured one; the range from low to high includes it.
By their numbers in this assay, from the lowest: compounds 1, 2 and 3 (each within the scatter of the next, the first and the last beyond it).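

Among these compounds, this is the first comparison that changes only one place. On this assay, putting 5-cyanopyridin-3-yl in place of 6-methoxypyridin-3-yl on this aromatic carbon gives a 2.0-fold higher number from compound 2 to compound 3 (0.30 log units; within the scatter). The two groups, which have the same count of heavy atoms and the same count of hydrogen-bond acceptors, therefore cannot be told apart on this read-out, and nothing shown accounts for the result.

A single swap between two substituted pyridines leaves open whether a different kind of group here, such as an amine or a carboxylic acid, would produce a step beyond the scatter. It also leaves open whether this same swap would give a similar result with a longer chain in place of the isopropyl group.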